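A Second Fluorine on the Phenethyl Arm

This account rests on a few compounds, and the source may have more. Where it says the series, first, only, none or still open, it means among the compounds named here.

Measured compounds in an in vitro assay on cells for displacement of a labelled ligand from thyroid hormone receptor beta (Homo sapiens), with a stated time of 48 h; a higher number here means a weaker inhibitor, a lower number a stronger inhibitor:
compound 1, `Cc1cc(NC(=O)CC(=O)O)c2c(c1Oc1ccc(O)c(CC(C)C)c1)CCC2`: 39.9 nM
compound 2, `Cc1cc(NC(=O)CC(=O)O)c2c(c1Oc1ccc(O)c(C(O)Cc3ccccc3)c1)CCC2`: 124 nM
compound 3, `Cc1cc(NC(=O)CC(=O)O)c2c(c1Oc1ccc(O)c(CCc3ccc(F)cc3)c1)CCC2`: 8.2 nM

Among the three numbers in this assay, compound 1 holds the second highest. Its nearest neighbour is compound 2, reached by a 3.1-fold higher number from compound 1 to compound 2 (0.49 log units; beyond the scatter); its furthest is compound 3, reached by a 4.9-fold lower number from compound 1 to compound 3 (0.69 log units; beyond the scatter). The step from compound 2 to compound 3 is the largest of the three, a 15-fold lower number from compound 2 to compound 3 (1.18 log units; beyond the scatter).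

Compound 4, `Cc1cc(NC(=O)CC(=O)O)c2c(c1Oc1ccc(O)c(CCc3ccc(F)cc3F)c1)CCC2`, is the next compound. Against compound 1 the difference is 2,4-difluorobenzyl in place of isopropyl on a saturated chain carbon bound to an aromatic carbon. Within the data shown here, the measured step that bears most directly on this change is the one from compound 1 to compound 3, a 4.9-fold lower number from compound 1 to compound 3 (0.69 log units; beyond the scatter), where the isopropyl likewise gave way to a fluorinated benzyl group; compound 4 carries one more fluorine on that ring, and no measured pair speaks to that added fluorine on its own. The step through compound 2, a 3.1-fold higher number from compound 1 to compound 2 (0.49 log units; beyond the scatter), involves a hydroxyl-bearing arm and is less informative here.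

Compound 4 is therefore expected to show a step of about a 4.4-fold lower number from compound 1 to compound 4 (0.65 log units; beyond the scatter), a lower number in this assay, close in size to what compound 3 showed. The estimate for compound 4 in this assay is 9 nM, with a range from 3 nM to 30 nM.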

Compound 4, inhibition constant: 12 nM
Compound 4: middle estimate off by 1.3-fold (0.12 log units), on the low side; low and high end bracket the measured number.
By their numbers in this assay, from the lowest: compounds 3 and 4 (each within the scatter of the next); then compound 1; then compound 2.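

In this assay, the second fluorine can now be read on its own: fluoro in place of hydrogen on an aromatic carbon gives a 1.5-fold higher number from compound 3 to compound 4 (0.17 log units; within the scatter), so this change does not separate the two compounds. The 2-(2,4-difluorophenyl)ethyl arm keeps its advantage over isobutyl, with a 3.3-fold lower number from compound 1 to compound 4 (0.52 log units; beyond the scatter), and over the hydroxyl-bearing arm, with a 10-fold lower number from compound 2 to compound 4 (1.01 log units; beyond the scatter), although that last pair differs in both the hydroxyl and the ring fluorines, so the step cannot be assigned to either alone. Nothing available explains these numbers.

From the compounds shown here alone, what a plain 2-phenylethyl arm, with no fluorine on its ring, would give remains open, and with it the contribution of the first fluorine and whether the hydroxyl alone sets compound 2 apart. Also open, going by these compounds, is how this position would respond to a chlorine, a methoxy group or an amine on the ring, or to a longer chain carrying that ring.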